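Nitro to trifluoromethyl to tert-butyl on the benzamide ring

This account rests on a few compounds, and the source may have more. Where it says the series, first, only, none or still open, it means among the compounds named here.

Two compounds of the series have been run in a functional assay on cells (Splenocyte, Mus musculus, strain BALB/c) for inhibition, read by scintillation counting and thymidine incorporation, with a stated time of 72 h; a higher number here means a weaker inhibitor, a lower number a stronger inhibitor. Compound 1 `CC(/C=N/Nc1ccc([N+](=O)[O-])cc1)=N\NC(=O)c1ccc([N+](=O)[O-])cc1` carries a nitro group on the amide-bearing aromatic ring, and in this assay compound 1 gives 980 nM. Compound 2 `CC(/C=N/Nc1ccc([N+](=O)[O-])cc1)=N\NC(=O)c1ccc(C(F)(F)F)cc1` differs by trifluoromethyl in place of nitro on an aromatic carbon. For compound 2 the readout is a limit and not a number, > 12000 nM. Compound 2 therefore stands at the limit of > 12000 nM in this assay, at which 1 of the 2 values shown sits. Going by the values given here, the measured step is an at least 12-fold higher number from compound 1 to compound 2 (1.08 log units; beyond the scatter), so the only change recorded so far on this ring moved the compound out of the measurable range.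

Compound 3 `CC(/C=N/Nc1ccc([N+](=O)[O-])cc1)=N\NC(=O)c1ccc(C(C)(C)C)cc1` is not yet measured. Its change from compound 2 is tert-butyl in place of trifluoromethyl on an aromatic carbon. Among the compounds with values here, the one measured step bears on it only indirectly: it shows that departing from nitro at this carbon cost a large step in this assay, but it gives no comparison between two non-nitro groups. Within the data shown here, with no step between such groups to lean on, compound 3 is expected to remain near the limit, and a number is expected only if the change is favourable: the estimated step is a step that the limit leaves unreadable from compound 2 to compound 3. Compound 3 is thus estimated at 15000 nM, within 4000 nM to 50000 nM.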

Compound 3, half-maximal inhibitory concentration: > 12000 nM
Compound 3: no number, only a limit (the forecaster's own chance of this, stated with the estimate: 65%); the middle value is on the limit's open side.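

Tert-butyl in place of nitro on an aromatic carbon gives an at least 12-fold higher number from compound 1 to compound 3 (1.08 log units; beyond the scatter) in this assay, so the loss at this carbon is no longer tied to trifluoromethyl alone. Compound 3 is reported only as a limit, and the step between trifluoromethyl and tert-butyl cannot be read. Among the compounds shown, only the nitro group at this carbon gives a number, while both replacements, neither with hydrogen-bond donors or acceptors, end at the same readout: the limit of > 12000 nM in this assay, at which 2 of the 3 values shown sit.

On these data alone, whether a nitrile, a carboxylic acid or an amine at this carbon would bring back a number in this assay stays open, as does any ranking of compound 2 and compound 3 beyond their shared limit. All three compounds also keep the nitro group on the other aromatic ring, so what that group contributes, and whether an amine or a nitrile could stand in its place, cannot be judged from these data.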